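Series notes: fluorophenoxy in place of fluorobenzylamino

The source may hold more compounds than are shown below. What is called first, only, known or untested is meant among the compounds shown, and "the series" means these compounds.

Measured so far:
compound 1 `COc1ccc(CNc2nc3cc(N)cc(N)c3nc2-c2ccccc2)cc1OC`; in a functional assay on ACHN cells (Homo sapiens) for inhibition, read by sulforhodamine B assay, with a stated time of 48 h (on this read-out lower numbers stand for stronger inhibition of growth and higher numbers for weaker inhibition of growth), compound 1 gives 33100 nM.
compound 2 `Nc1cc(N)c2nc(-c3ccccc3)c(NCc3ccc(F)cc3)nc2c1`; in this assay compound 2 gives 3090 nM.
compound 3 `COc1ccc(CNc2nc3cc(N)cc(N)c3nc2-c2ccccc2)cc1`; in this assay compound 3 gives 33900 nM.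

Compound 2 stands lowest of the three: an 11-fold lower number from compound 1 to compound 2 (1.03 log units; beyond the scatter) and an 11-fold higher number from compound 2 to compound 3 (1.04 log units; beyond the scatter) both set it well apart, while a 1.0-fold higher number from compound 1 to compound 3 (0.01 log units; within the scatter) leaves compounds 1 and 3 indistinguishable.

Compound 4 `Nc1cc(N)c2nc(-c3ccccc3)c(Oc3ccc(F)cc3)nc2c1` differs from compound 2 by 4-fluorophenoxy in place of (4-fluorobenzyl)amino on an aromatic carbon. Going by the values given here, none of the measured steps bears on this change: all three vary only the substituents on the pendant aromatic ring and keep the (4-fluorobenzyl)amino linker intact. The expectation therefore rests on compound 2 alone, with wide uncertainty; a modest move to a higher number is expected, a 2.6-fold higher number from compound 2 to compound 4 (0.41 log units; beyond the scatter).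

Compound 4 is estimated at 8000 nM, range 2500 nM to 30000 nM.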

Compound 4, concentration for total growth inhibition: 33100 nM
Beside the measured number, compound 4's estimate is 4.1-fold (0.62 log units) below it; the whole stated range lies below it.
By their numbers in this assay, from the lowest: compound 2; then compounds 1, 4 and 3 (each within the scatter of the next).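

At this aromatic carbon the link itself counts, not only the substituents on the pendant ring: in this assay there is an 11-fold higher number from compound 2 to compound 4 (1.03 log units; beyond the scatter), with the 4-fluorophenyl ring kept on both sides. The change removes the hydrogen-bond donor and goes from 9 to 8 heavy atoms. Nothing measured here accounts for the step.

As far as these compounds go, the linking atom and the chain length change together, so the share of each stays open. A 4-fluorobenzyloxy or 4-fluoroanilino group at this carbon would separate the two.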